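Swapping 2-methylphenyl for pyridin-2-yl on a shared core

A few compounds are considered here, and "the series" means these few. Any claim that something is new, unique, unknown or untested is made for them only; others in the source may bear on it.

Compound 1 `Cc1ccsc1-c1cc(-c2ccco2)cc(-c2ccc(Cl)cc2)n1`: 26700 nM
Compound 2 `Cc1ccccc1-c1cc(-c2ccoc2)cc(-c2ccc(Cl)s2)n1`: 18500 nM

In a functional assay on DU-145 cells (Homo sapiens) for cytotoxicity, read by ELISA, with a stated time of 4 days (a higher number here means a weaker inhibitor, a lower number a stronger inhibitor), compound 2 gives 18500 nM, and this lies within the usual scatter of compound 1 at 26700 nM. Compound 3 `Clc1ccc(-c2cc(-c3ccoc3)cc(-c3ccccn3)n2)s1` has pyridin-2-yl in place of the 2-methylphenyl of compound 2, on an aromatic carbon next to the ring nitrogen (pyridin-2-yl in place of 2-methylphenyl on an aromatic carbon). For the measured compounds named here, no measured pair here shows what this change does, so no shift beyond the scatter is expected. The expected change is a 1.2-fold lower number from compound 2 to compound 3 (0.06 log units; within the scatter). For compound 3 the estimated value is 16000 nM, with an expected range from 5500 nM to 45000 nM.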

Compound 3, half-maximal inhibitory concentration: 20500 nM
For compound 3 the middle estimate is 1.3-fold (0.11 log units) below the measured one; low and high end bracket the measured number.
By their numbers in this assay, from the lowest: compounds 2, 3 and 1 (each within the scatter of the next).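

For the compounds shown here, this is the first direct comparison at this position, on an aromatic carbon next to the ring nitrogen. In this assay, pyridin-2-yl in place of 2-methylphenyl gives a 1.1-fold higher number from compound 2 to compound 3 (0.04 log units; within the scatter), so a ring with one hydrogen-bond acceptor reads the same here as the carbon-only ring. Nothing available gives a reason for this result.

Still open, going by these compounds, is whether a group of another kind at this position, such as an amine or a carboxylic acid, would move the number beyond the scatter. One swap also cannot show whether pyridin-2-yl would read the same on another core.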